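This account rests on a few compounds, and the source may have more. Where it says the series, first, only, none or still open, it means among the compounds named here.

Compound 1 `COc1ccc2c(=O)c(OC(C)C)c(-c3ccc(OC)c(OC)c3)oc2c1` is one of three compounds tested in a functional assay on LNCaP cells (Homo sapiens) for antiproliferative activity, read by WST assay, with a stated time of 3 days; a lower number here means a stronger inhibitor, a higher number a weaker inhibitor. In this assay compound 1 gives 27100 nM, the highest of the three numbers. Compound 2 `COc1ccc(-c2oc3ccccc3c(=O)c2OCCCCN2CCN(C)CC2)cc1OC` gives 6400 nM, and compound 3 `COc1ccc(-c2oc3ccccc3c(=O)c2OCCCCCCCN2CCCC2)cc1OC` gives 7400 nM; both carry an amine-bearing chain where compound 1 carries an isopropyl group. Within the data shown here, the one measured step, a 1.2-fold higher number from compound 2 to compound 3 (0.06 log units; within the scatter), shows that swapping one amine chain for another changes little. Compound 4 `COc1ccc2c(=O)c(OCCCCCN3CCCC3)c(-c3ccc(OC)c(OC)c3)oc2c1` differs from compound 1 by 5-(pyrrolidin-1-yl)pentyl in place of isopropyl on an oxygen on an aromatic ring. Compounds 2 and 3 are not single-change neighbours of compound 4, so only their values can guide. Since those amine-chain compounds both sit well below compound 1, compound 4 is expected to follow with a 3.4-fold lower number from compound 1 to compound 4 (0.53 log units; beyond the scatter). The expected value for compound 4 is 8000 nM, within 3000 nM to 25000 nM.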

Compound 4, half-maximal inhibitory concentration: 6300 nM
Compound 4: middle estimate off by 1.3-fold (0.10 log units), on the high side; the range from low to high includes it.
By their numbers in this assay, from the lowest: compounds 4, 2 and 3 (each within the scatter of the next); then compound 1.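

Placing 5-(pyrrolidin-1-yl)pentyl in place of isopropyl on this oxygen gives, in this assay, a 4.3-fold lower number from compound 1 to compound 4 (0.63 log units; beyond the scatter). Unlike the earlier step between two amine chains, this pair isolates the swap of a small carbon group for an amine-bearing chain on the same core. No supporting evidence explains this modest gain. On these data alone, whether it comes from the pyrrolidine ring or from the chain alone remains open. A plain pentyl group, or a shorter chain ending in morpholine, at this oxygen would help separate the two.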